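Anilino-thiophene series: 4-fluorophenyl replacing 4-methoxyphenyl

This account rests on a few compounds, and the source may have more. Where it says the series, first, only, none or still open, it means among the compounds named here.

Measured so far:
compound 1 `COC(=O)c1c(Nc2ccc(C)cc2)sc(C(=O)c2ccc(OC)cc2)c1C` — "not active" (no number reported)
compound 2 `COC(=O)c1c(Nc2ccc(OC)cc2)sc(C(=O)c2ccc(OC)cc2)c1C` — 15.5%

Of the compounds shown here, two of the shared core have been measured in a functional assay, with a stated time of 150 min, tested at 25 ug/mL; on this read-out higher numbers stand for a stronger effect at the one concentration tested and lower numbers for a weaker effect. Compound 1 `COC(=O)c1c(Nc2ccc(C)cc2)sc(C(=O)c2ccc(OC)cc2)c1C` carries a methyl group on the aniline ring and gives "not active" (no number reported), so it contributes no number. Compound 2 `COC(=O)c1c(Nc2ccc(OC)cc2)sc(C(=O)c2ccc(OC)cc2)c1C` carries a methoxy group in the same position and gives 15.5%. Within the data shown here, compound 2 therefore stands as the only entry with a number in this assay; the second entry offers no number to compare it against, so no step between measured compounds can be stated.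

Compound 3 `COC(=O)c1c(Nc2ccc(F)cc2)sc(C(=O)c2ccc(OC)cc2)c1C` is not yet measured. It differs from compound 2 in one place: fluoro in place of methoxy on an aromatic carbon. Among the measured compounds shown here, no measured pair shows this kind of exchange, so the size of its effect in this assay is open. Because compound 1 gives "not active" (no number reported) without the methoxy group, a loss of some of the activity seen for compound 2 is expected, though a change within the scatter is also possible. The estimated step from compound 2 to compound 3 is a number 7.5 percentage points lower from compound 2 to compound 3 (within the scatter). Compound 3 is expected to give 8%, in the range 0% to 20%.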

Compound 3, a percentage reported as activity, at one concentration (the size of the read-out at that concentration, not a potency): 20.2%
The estimate for compound 3 lay 12.2 percentage points below the measured number; measured number above the stated range.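

In this assay the exchange of methoxy for fluoro gives a number 4.7 percentage points higher from compound 2 to compound 3 (within the scatter) and so does not separate the two compounds on this read-out. Among these compounds, the methoxy group is thus not needed for a numerical read-out at this position, even though the 4-fluorophenyl group brings one heavy atom in place of two and no hydrogen-bond acceptor by the count used here; with a methyl group in the same place, compound 1 gives "not active" (no number reported) and remains the only entry without a number. Nothing available bears on why these groups give these results.

Still open, on these data alone, is whether an amine, a carboxylic acid or a longer alkoxy chain on this aromatic carbon would keep a numerical read-out, and whether any group here would yield a step beyond the scatter. Among the compounds shown here, with fluoro and methoxy as the only groups at this position that give numbers, and with each compound read at one concentration, these data cannot define a trend for the position or give a potency for any compound.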